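A few compounds are considered here, and "the series" means these few. Any claim that something is new, unique, unknown or untested is made for them only; others in the source may bear on it.

Working notes on the series. In a functional assay on HT-1080 cells (Homo sapiens) for antiproliferative activity, read by MTT assay, with a stated time of 72 h (on this read-out lower numbers stand for stronger inhibition and higher numbers for weaker inhibition), compound 1 (`COc1ccc(-c2c(-c3cc(OC)c(OC)c(OC)c3)ssc2=S)cc1[N+](=O)[O-]`) gives 3550 nM as its half-maximal inhibitory concentration. Compound 2 (`COc1ccc(-c2ssc(=O)c2-c2cc(OC)c(OC)c(OC)c2)cc1`) gives 464 nM in the same test. That is the lower of the two numbers, and its gap to compound 1 lies beyond the scatter. Going by the values given here, these two compounds differ in more than one place, and no measured pair isolates a single change.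

Compound 3 (`COc1ccc(-c2ssc(=O)c2-c2cc(OC)c(OC)c(OC)c2)cc1O`) departs from compound 2 in one place only: hydroxy in place of hydrogen on an aromatic carbon with hydroxy in place of hydrogen on an aromatic carbon, ortho to a methoxy group. This turns 4-methoxyphenyl into 3-hydroxy-4-methoxyphenyl. Among the compounds with values here, the series holds no measured example of this change, and the direction below remains a judgement with wide margins. In this assay a moderate move towards stronger inhibition is expected, although a result within the scatter of compound 2 cannot be excluded. The estimated change is a 3.1-fold lower number from compound 2 to compound 3 (0.49 log units; beyond the scatter) on this reading. For compound 3 an estimated 150 nM is expected, with a range from 30 nM to 700 nM around it.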

Compound 3, half-maximal inhibitory concentration: 1910 nM
The estimate for compound 3 lay 13-fold (1.10 log units) below the measured number; the whole stated range lies below it.
By their numbers in this assay, from the lowest: compound 2; then compounds 3 and 1 (each within the scatter of the next).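

In this assay, hydroxy in place of hydrogen on this aromatic carbon, ortho to a methoxy group, gives a 4.1-fold higher number from compound 2 to compound 3 (0.61 log units; beyond the scatter), a modest move towards weaker inhibition. Going by these compounds alone, this is the first comparison that isolates a single change, and it shows that this position on the 4-methoxyphenyl group responds to substitution, since one added hydroxy shifts the number beyond the scatter. Within this pair, the compound with hydrogen at this carbon, compound 2, has the lower number, and the step runs against any reading of this hydroxy as a gain in this assay. Nothing at hand bears on the reason for the shift.

A single substituent cannot show whether the shift is particular to hydroxy or would also appear with another group at the same carbon, such as an amine, a fluorine atom or an ethoxy group. On these data alone, it also remains open whether the same change would move the number in the same direction on the core of compound 1, or at another carbon of the 4-methoxyphenyl group.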